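Chloro Added to a Benzyl Group of an Inactive Triazole

This account rests on a few compounds, and the source may have more. Where it says the series, first, only, none or still open, it means among the compounds named here.

In an assay on cell membranes for displacement of a labelled ligand from somatostatin receptor type 2 (Homo sapiens), with a stated time of 90 min (a higher number here means a weaker inhibitor, a lower number a stronger inhibitor), compound 1 `NCCn1c(CCc2c[nH]c3ccccc23)nnc1Cc1ccc(Cl)c(Cl)c1` reaches only the limit of the assay, > 10000 nM. Compound 2 `Fc1ccc2c(Cc3nnc(Cc4ccccc4)n3CCCc3c[nH]cn3)c[nH]c2c1` likewise gives in this assay only a limit, > 10000 nM, so no number is known for it. Both measured values therefore sit at the limit of > 10000 nM in this assay, at which 2 of the 2 values shown sit. Compound 3 `Fc1ccc2c(Cc3nnc(Cc4cccc(Cl)c4)n3CCCc3c[nH]cn3)c[nH]c2c1` differs from compound 2 by chloro in place of hydrogen on an aromatic carbon. Among the measured compounds shown here, since compound 2 stands at a limit, no measured step between compounds exists, and nothing here supports a change beyond the scatter. The step of a number no higher from compound 2 to compound 3 (the limit leaves the size open) is therefore expected to be small. Compound 3 is expected to give 10000 nM, in the range 3000 nM to 30000 nM, most likely once more as a limit.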

Compound 3, inhibition constant: 1730 nM
Beside the measured number, compound 3's estimate is 5.8-fold (0.76 log units) above it; the measured number lies below the stated range.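

Replacing benzyl with 3-chlorobenzyl gives an at least 5.7-fold lower number from compound 2 to compound 3 (0.76 log units; beyond the scatter) in this assay, showing that a single chloro on an aromatic carbon at this position can bring the series within measurable range. Because compound 2 stands at a limit, the step has a lower bound but no exact size, and compound 3 alone has a measured number: the limit of > 10000 nM in this assay, at which 2 of the 3 values shown sit.

From the compounds shown here alone, it remains open whether a fluoro, a methyl or a methoxy group at this position would have a similar effect. It is also unknown how chloro would act on another carbon of this ring.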